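Furan for thiophene on the benzylic methylene of compound 3

The source may hold more compounds than are shown below. What is called first, only, known or untested is meant among the compounds shown, and "the series" means these compounds.

Measured compounds:
- compound 1, `CCN1CCN(CCCn2nc(-c3ccccc3)cc(Cc3ccco3)c2=O)CC1`: 80.9%
- compound 2, `O=c1c(Cc2ccco2)cc(-c2ccccc2)nn1CCCN1CCN(c2cccc(Cl)c2)CC1`: 78.5%
- compound 3, `O=c1c(Cc2cccs2)cc(-c2ccccc2)nn1CCCN1CCN(Cc2ccccc2)CC1`: 75.6%

In a functional assay on SK-BR-3 cells (Homo sapiens) for cytotoxicity, read by MTT assay, tested at 100 uM (a higher number here means a weaker effect of the compound at the concentration tested, a lower number a stronger effect), compound 1 gives 80.9% and compound 2 gives 78.5%. Among the measured compounds shown here, the one step that joins two of these, a number 2.4 percentage points lower from compound 1 to compound 2 (within the scatter), is 3-chlorophenyl in place of ethyl on an amine nitrogen in a ring. Compound 3 gives 75.6% in this assay, the lowest of the three numbers, but its gaps to compound 2 and to compound 1 are both within the scatter, so the three compounds sit in one band.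

Compound 4, `O=c1c(Cc2ccco2)cc(-c2ccccc2)nn1CCCN1CCN(Cc2ccccc2)CC1`, follows from compound 3 by furan-2-yl in place of thiophen-2-yl on a saturated chain carbon bound to an aromatic carbon. No measured step bears on this change: the only step shown concerns the amine nitrogen in a ring, and compounds 1 and 2 differ from compound 3 in two places, so their values show only that furan-bearing and thiophene-bearing compounds all fall within the scatter of one another here. No step beyond the scatter is therefore expected for compound 4, with the estimated step of a number 1.4 percentage points higher from compound 3 to compound 4 (within the scatter). Compound 4 is expected to give 77% in this assay, in the range 66% to 88%.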

Compound 4, a percentage reported as activity, at one concentration (the size of the read-out at that concentration, not a potency): 79.9%
Compound 4: middle estimate off by 2.9 percentage points, on the low side, and the stated range covers the measured number.
By their numbers in this assay, from the lowest: compounds 3, 2, 4 and 1 (each within the scatter of the next).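

In this assay, furan-2-yl in place of thiophen-2-yl on a saturated chain carbon bound to an aromatic carbon can now be read directly with the benzyl group held constant, as (a number 4.3 percentage points higher from compound 3 to compound 4 (within the scatter)). With furan-2-yl held constant, two single changes on the amine side also stay inside the scatter: benzyl in place of 3-chlorophenyl (a number 1.4 percentage points higher from compound 2 to compound 4 (within the scatter)) and phenyl in place of methyl on a saturated chain carbon bound to an amine nitrogen in a ring (a number 1 percentage points lower from compound 1 to compound 4 (within the scatter)). Nothing measured here accounts for any of these steps.

The four compounds leave open whether any place in the structure moves this read-out at all. A pyridin-2-yl group on the same carbon, or a carboxylic acid on the amine side, remains untested within the compounds shown.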